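From 2-fluorophenyl to 3-cyanophenyl on a carbonyl carbon

The compounds below may be only part of what the source reports. "The series", "measured", "known", "first", "only" and "open" are said of these compounds alone.

Compound 1 (`Cc1ccc(S(=O)(=O)N[C@@H](CC(=O)NC(C)(C)C)C(=O)NCCNC(=O)c2ccccc2)cc1`) gives > 11000 nM in an ADME assay on HepG2 cells (Homo sapiens) for cytotoxicity (a higher number here means that more compound is needed for the effect, a lower number that less compound is needed), and this is a limit of the assay, not a number. Compound 2 (`Cc1ccc(S(=O)(=O)N[C@@H](CC(=O)NC(C)(C)C)C(=O)NCCNC(=O)c2cccc(C(C)C)c2)cc1`) gives > 11000 nM there, again only a limit. Compound 3 (`Cc1ccc(S(=O)(=O)N[C@@H](CC(=O)NC(C)(C)C)C(=O)NCCNC(=O)c2ccccc2F)cc1`) gives > 11000 nM too, and this is also only a limit. Compound 3 therefore stands level with the other two, with no number of its own (the limit of > 11000 nM in this assay, at which 3 of the 3 values shown sit).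

Compound 4 (`Cc1ccc(S(=O)(=O)N[C@@H](CC(=O)NC(C)(C)C)C(=O)NCCNC(=O)c2cccc(C#N)c2)cc1`) has not yet been measured. It keeps the shared core and carries 3-cyanophenyl in place of 2-fluorophenyl on a carbonyl carbon.

Within the data shown here, three measured steps bear on this change: a step that the two limits leave unreadable from compound 1 to compound 2 for isopropyl in place of hydrogen, a step that the two limits leave unreadable from compound 1 to compound 3 for fluoro in place of hydrogen, and a step that the two limits leave unreadable from compound 2 to compound 3 for 2-fluorophenyl in place of 3-isopropylphenyl. None of their sizes can be read, but compound 1, compound 2 and compound 3 all remain at the limit, and none of the three goes against this. A further result at the limit is therefore the likeliest outcome, and no direction of change can be expected with any confidence. The expected outcome is a step that the limit leaves unreadable from compound 3 to compound 4 (an estimate only). For compound 4 the estimate is 15000 nM (expected range 9000 nM to 30000 nM).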

Compound 4, half-maximal effective concentration: > 11000 nM
Compound 4 gave a limit, no number (the forecaster's own chance of this, stated with the estimate: 90%); the middle value lies beyond the limit too.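

No step can be read from compound 1, compound 2 or compound 3 to compound 4, because each result is a limit and not a number: the limit of > 11000 nM in this assay, at which 4 of the 4 values shown sit.

In this assay the compounds shown leave open how much of each compound is needed for the effect, and so whether these group changes alter it at all.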